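Series notes: methoxy on the phenyl of compound 3

This account rests on a few compounds, and the source may have more. Where it says the series, first, only, none or still open, it means among the compounds named here.

Of the compounds shown here, three of the shared core have been measured in an assay on isolated protein for inhibition of steroid 5-alpha-reductase (Rattus norvegicus); a lower number here means a stronger inhibitor, a higher number a weaker inhibitor. Compound 1 `COc1ccccc1N1CCN(CCCCOc2ccc(C(=O)Nc3ccccc3OCCCC(=O)O)cc2)CC1` gives 43000 nM in this assay. Compound 2 `COc1ccccc1N1CCN(CCCCCCOc2ccc(C(=O)Nc3ccccc3OCCCC(=O)O)cc2)CC1` gives 9500 nM. Compound 3 `COc1ccccc1N1CCN(CCC(Oc2ccc(C(=O)Nc3ccccc3OCCCC(=O)O)cc2)c2ccccc2)CC1` gives 1000 nM, the lowest number of the three; its gaps to compound 2 and to compound 1 both lie beyond the scatter of this assay, so compound 3 stands as the strongest inhibitor among the measured set.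

Compound 4 `COc1ccc(C(CCN2CCN(c3ccccc3OC)CC2)Oc2ccc(C(=O)Nc3ccccc3OCCCC(=O)O)cc2)cc1` differs from compound 3 in one place: methoxy in place of hydrogen on an aromatic carbon. For the measured compounds named here, no measured pair carries this same change, so the series itself gives no size for it. The step from compound 3 to compound 4 in this assay is expected to be small, with no clear direction, and most likely within the scatter; the expected step is a 1.3-fold lower number from compound 3 to compound 4 (0.10 log units; within the scatter). On that basis compound 4 is estimated at 800 nM in this assay, with a range from 250 nM to 2500 nM.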

Compound 4, half-maximal inhibitory concentration: 170 nM
The estimate for compound 4 lay 4.7-fold (0.67 log units) above the measured number, and the stated range ends above it.
By their numbers in this assay, from the lowest: compound 4; then compound 3; then compound 2; then compound 1.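

In this assay the change from phenyl to 4-methoxyphenyl gives a 5.9-fold lower number from compound 3 to compound 4 (0.77 log units; beyond the scatter), so this place, para to a large group, responds to substitution with a group of only 2 heavy atoms. Among the earlier compounds only compound 3 carries this phenyl, and it has hydrogen here, so they gave no reading of what a substituent at this place does. Nothing at hand bears on the origin of this step.

As far as these compounds go, whether the lower number is particular to methoxy remains open, since a hydroxyl, a fluorine, an ethoxy or a dimethylamino group at the same place would separate the methoxy from other substituents. Also open, from the compounds shown here alone, is whether the same step would appear with methoxy on another carbon of this ring.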